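This account rests on a few compounds, and the source may have more. Where it says the series, first, only, none or still open, it means among the compounds named here.

Compound 1 `CC(/C=C/[C@@]1(O)C(C)(C)CCC[C@@]1(C)O)=C\C(=O)O[C@@H]1C[C@](C)(O)[C@H]2[C@H](O[C@@H]3O[C@H](CO)[C@@H](O)[C@H](O)[C@H]3O)OC=C[C@H]21` gives > 10000 nM in a functional assay on A549 cells (Homo sapiens) for cytotoxicity, read by MTT assay, with a stated time of 4 days (a lower number here means a stronger inhibitor, a higher number a weaker inhibitor), which is a limit of the assay, not a number.
Compound 2 `CC(/C=C/[C@@]1(O)C(C)(C)C[C@H](O)C[C@@]1(C)O)=C\C(=O)O[C@@H]1C[C@](C)(O)[C@H]2[C@H](O[C@@H]3O[C@H](CO)[C@@H](O)[C@H](O)[C@H]3O)OC=C[C@H]21` gives > 10000 nM in this assay, again a limit of the assay.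
Compound 3 `CC(/C=C/[C@@]1(O)C(C)(C)CC[C@@H](O)[C@@]1(C)O)=C\C(=O)O[C@@H]1C[C@](C)(O)[C@H]2[C@H](O[C@@H]3O[C@H](CO)[C@@H](O)[C@H](O)[C@H]3O)OC=C[C@H]21` gives > 10000 nM in this assay, also a limit of the assay.

Compound 1 thus stands at the limit together with the other two: the limit of > 10000 nM in this assay, at which 3 of the 3 values shown sit. The steps a step that the two limits leave unreadable from compound 1 to compound 2 and a step that the two limits leave unreadable from compound 1 to compound 3 cannot be read, and a step that the two limits leave unreadable from compound 2 to compound 3 is likewise unreadable. Compound 4 `CC(/C=C/[C@@]1(O)C(C)(C)CCC[C@@]1(C)O[C@@H]1O[C@H](CO)[C@@H](O)[C@H](O)[C@H]1O)=C\C(=O)O[C@@H]1C[C@](C)(O)[C@H]2[C@H](O[C@@H]3O[C@H](CO)[C@@H](O)[C@H](O)[C@H]3O)OC=C[C@H]21` differs from compound 1 in one place: 3,4,5-trihydroxy-6-(hydroxymethyl)oxan-2-yl in place of hydrogen on an oxygen on a saturated carbon. Among the measured compounds shown here, no measured step bears directly on this change. Since every measured value sits at the limit, compound 4 is expected to stay there as well, with an expected step that the limit leaves unreadable from compound 1 to compound 4. The estimate for compound 4 is 20000 nM, with a range from 8000 nM to 100000 nM.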

Compound 4, half-maximal inhibitory concentration: > 10000 nM
Compound 4: no number, only a limit; the forecaster's own chance of this, stated with the estimate: 85%; the middle value does not contradict the limit.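

No new step can be read, since compound 1 and compound 4 both stand at a limit: the limit of > 10000 nM in this assay, at which 4 of the 4 values shown sit. The compounds shown leave open which change to the shared core, if any, would give a real number in this assay.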